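From Dimethylphenyl to Difluorophenyl: An Antiproliferative Estimate

The source may hold more compounds than are shown below. What is called first, only, known or untested is meant among the compounds shown, and "the series" means these compounds.

Measured compounds:
compound 1 `Cn1c(=O)c(=O)n(C2CCCC2)c2nc(N/N=C/c3cccc(Cl)c3Cl)ncc21` — 39100 nM
compound 2 `Cn1c(=O)c(=O)n(C2CCCC2)c2nc(N/N=C/c3ccco3)ncc21` — a limit of the assay, > 100000 nM
compound 3 `Cc1ccc(/C=N/Nc2ncc3c(n2)n(C2CCCC2)c(=O)c(=O)n3C)cc1C` — 30200 nM

In a functional assay on A549 cells (Homo sapiens) for antiproliferative activity, read by MTT assay (a lower number here means a stronger inhibitor, a higher number a weaker inhibitor), compound 3 gives 30200 nM. Compound 1 sits close to it, since the step of a 1.3-fold lower number from compound 1 to compound 3 (0.11 log units; within the scatter) lies within the scatter. For compound 2 the assay reports only a limit, > 100000 nM, as noted in the limit of > 100000 nM in this assay, at which 1 of the 3 values shown sits; the step of an at least 3.3-fold lower number from compound 2 to compound 3 (0.51 log units; beyond the scatter) is therefore at least modest.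

Compound 4 `Cn1c(=O)c(=O)n(C2CCCC2)c2nc(N/N=C/c3ccc(F)cc3F)ncc21` differs from compound 3 by 2,4-difluorophenyl in place of 3,4-dimethylphenyl on a carbon with a double bond to nitrogen. The nearest measured step is a 1.3-fold lower number from compound 1 to compound 3 (0.11 log units; within the scatter), where one six-membered carbon ring replaced another without moving beyond the scatter. Compound 4 is therefore expected to stay near compound 3, with a 1.3-fold higher number from compound 3 to compound 4 (0.12 log units; within the scatter) not beyond the scatter. Compound 4 is estimated at 40000 nM, between 15000 nM and 100000 nM.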

Compound 4, half-maximal inhibitory concentration: 18300 nM
Estimate against measurement, compound 4: 2.2-fold (0.34 log units) above; the measured number falls inside the stated range.
By their numbers in this assay, from the lowest: compounds 4, 3 and 1 (each within the scatter of the next, the first and the last beyond it). At a limit, above all of these: compound 2.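

With 2,4-difluorophenyl on a carbon with a double bond to nitrogen, one six-membered carbon ring now differs from another beyond the scatter (a 2.1-fold lower number from compound 1 to compound 4 (0.33 log units; beyond the scatter)), although the step is modest. The other such comparison stays within the scatter (a 1.7-fold lower number from compound 3 to compound 4 (0.22 log units; within the scatter)). The step from furan-2-yl (an at least 5.4-fold lower number from compound 2 to compound 4 (0.73 log units; beyond the scatter)) is only a bound, since compound 2 is a limit: the limit of > 100000 nM in this assay, at which 1 of the 4 values shown sits.

As far as these compounds go, whether the number would move further with an amine or a carboxylic acid on the phenyl ring remains open. So does whether a longer chain in place of cyclopentyl would change it.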